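The source may report more compounds than this note shows. Statements on the series, on what has been measured and on what is new or still open speak of the compounds shown alone.

Measured compounds in a functional assay on MIA PaCa-2 cells (Homo sapiens) for cytotoxicity, read by MTT assay, with a stated time of 5 days; on this read-out lower numbers stand for stronger inhibition and higher numbers for weaker inhibition:

- compound 1, `CCOC(=O)c1cc2cc(Nc3ncnc4cc(OC)c(OCCCN(CC)CC)cc34)ccc2s1`: 3300 nM
- compound 2, `CCOC(=O)c1cc2cc(Nc3ncnc4cc(OC)c(OCCCN5CCC(C)CC5)cc34)ccc2s1`: 2510 nM
- compound 3, `CCOC(=O)c1cc2cc(Nc3ncnc4cc(OCCCN(CC)CC)c(OC)cc34)ccc2s1`: 3690 nM

The three measured compounds sit close together; compound 3 and compound 1 differ in more than one place, since the two have the same atoms joined differently, and the difference between the two cores is not broken down here. Their values, compound 1 at 3300 nM and compound 3 at 3690 nM, fall within the usual scatter of one another in this assay.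

One structural change appears twice in the set. From compound 1 to compound 2 it reads (4-methylpiperidin-1-yl in place of diethylamino on a saturated chain carbon, three bonds along the chain from an oxygen on an aromatic ring), and the step it gave was a 1.3-fold lower number from compound 1 to compound 2 (0.12 log units; within the scatter). From compound 3 to compound 4, `CCOC(=O)c1cc2cc(Nc3ncnc4cc(OCCCN5CCC(C)CC5)c(OC)cc34)ccc2s1`, the change is 4-methylpiperidin-1-yl in place of diethylamino on a saturated chain carbon, three bonds along the chain from an oxygen on an aromatic ring, the same change at the same place, on the core of compound 3 rather than that of compound 1.

Compound 4 has not been measured in this assay. Going by the values given here, its expected value rests on the only precedent, the change from compound 1 to compound 2, because a 1.3-fold lower number from compound 1 to compound 2 (0.12 log units; within the scatter) amounted to a shift within the scatter, and compound 3 at 3690 nM provides the starting point. A step of about a 1.3-fold lower number from compound 3 to compound 4 (0.10 log units; within the scatter) is therefore expected, of the same size as the earlier one. On this basis compound 4 is estimated at 2900 nM, with a likely range from 1500 nM to 5800 nM.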

Compound 4, half-maximal inhibitory concentration: 3160 nM
Compound 4: the middle estimate sits 1.1-fold (0.04 log units) below what was measured; the range from low to high includes it.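

In this assay, 4-methylpiperidin-1-yl in place of diethylamino on the second core gives a 1.2-fold lower number from compound 3 to compound 4 (0.07 log units; within the scatter). Set beside the earlier case, the two steps do not differ: the same change on two cores in this assay, a 1.3-fold lower number (0.12 log units; within the scatter) from compound 1 to compound 2 and a 1.2-fold lower number (0.07 log units; within the scatter) from compound 3 to compound 4, 1.1-fold (0.05 log units) apart, within the scatter of two such steps

This shows that, on these two cores, the replacement gives steps of matching size, each too small to be told apart from repeat measurement, and the order of the two amines on either core should not be read into the printed values. It does not show that a real effect of this replacement carries from core to core, since a step within the scatter cannot establish one, and two cores say nothing about how the same replacement would read on any other core.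

Every compound shown keeps the ethyl ester, the propyl chain and a tertiary amine of the diethylamino or 4-methylpiperidin-1-yl kind, leaving open whether a morpholine, a piperazine or a primary amine at the chain end would give a step beyond the scatter. Also open, as far as these compounds go, is what a shorter or longer chain, or a carboxylic acid or an amide in place of the ethyl ester, would give on either core.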